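Dimethoxyphenyl to Hydroxyphenyl: Expected Gain in Growth Inhibition

A few compounds are considered here, and "the series" means these few. Any claim that something is new, unique, unknown or untested is made for them only; others in the source may bear on it.

Measured compounds:
compound 1 `COc1ccc(Nc2nc(N[C@H]3CC[C@H](N)CC3)nc3c2ncn3CCC(C)C)c(OC)c1`: 630 nM
compound 2 `CC(C)=CCn1cnc2c(Nc3cccc(Cl)c3)nc(N[C@H]3CC[C@H](N)CC3)nc21`: 80 nM
compound 3 `CCCCn1cnc2c(Nc3ccccc3)nc(N[C@H]3CC[C@H](N)CC3)nc21`: 20 nM

In a functional assay on EOL1 cells (Homo sapiens) for inhibition, read by fluorescence, with a stated time of 72 h (a lower number here means a stronger inhibitor of growth, a higher number a weaker inhibitor of growth), compound 1 gives 630 nM, the highest of the three numbers. Compound 2 gives 80 nM in this assay, beyond the scatter below compound 1. Compound 3 gives 20 nM in this assay, further still from compound 1.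

Compound 4 `CC(C)CCn1cnc2c(Nc3ccc(O)cc3)nc(N[C@H]3CC[C@H](N)CC3)nc21` differs from compound 1 by 4-hydroxyphenyl in place of 2,4-dimethoxyphenyl on a nitrogen on an aromatic ring. Within the data shown here, no measured pair shows this change directly. The two compounds without the 2,4-dimethoxyphenyl both give lower numbers, so the step of a 6.3-fold lower number from compound 1 to compound 4 (0.80 log units; beyond the scatter) is expected to be beyond the scatter, toward a lower number. Compound 4 is therefore estimated at 100 nM, with a range from 25 nM to 400 nM.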

Compound 4, concentration for 50% growth inhibition: 30 nM
For compound 4 the middle estimate is 3.3-fold (0.52 log units) above the measured one; measured number inside the range.
By their numbers in this assay, from the lowest: compounds 3 and 4 (each within the scatter of the next); then compound 2; then compound 1.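

In this assay, 4-hydroxyphenyl in place of 2,4-dimethoxyphenyl gives a 21-fold lower number from compound 1 to compound 4 (1.32 log units; beyond the scatter), a large step. Among these compounds, this is the first reading in which only the group on this nitrogen changes, and it shows that growth inhibition responds strongly to that group while the rest of the molecule stays the same. No measurement available here accounts for the size of the step.

The change removes one methoxy group and replaces the other with hydroxyl, so the compounds shown do not separate the two parts. They also leave open how a 4-methoxyphenyl or 4-aminophenyl group would fare at this position.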